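Working notes on compounds 1 to 4

The compounds below may be only part of what the source reports. "The series", "measured", "known", "first", "only" and "open" are said of these compounds alone.

compound 1 `COc1ccc(C(=O)/C=C/c2cc(OC)c(OC)c(OC)c2)c2c1C=CC(C)(C)O2` — 7650 nM
compound 2 `COc1cc(OC)c(OC)cc1/C=C/C(=O)c1ccc(OC)c2c1OC(C)(C)C=C2` — > 10000 nM
compound 3 `COc1ccc(C(=O)/C=C/c2ccc(F)cc2)c2c1C=CC(C)(C)O2` — > 10000 nM

In a functional assay on HCT-116 cells (Homo sapiens) for antiproliferative activity, read by MTT assay, with a stated time of 24 h (a lower number here means a stronger inhibitor, a higher number a weaker inhibitor), compound 1 gives 7650 nM. For compound 2 the result is a limit of the assay, > 10000 nM. For compound 3 the result is likewise only a limit, > 10000 nM. Among the compounds with values here, compound 3 thus stands at the limit of > 10000 nM in this assay, at which 2 of the 3 values shown sit; its value cannot be placed in order against compound 2, and against compound 1 the two values show only that compound 1 has a number while compound 3 has none.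

Compound 4 `CCN(CC)c1ccc(/C=C/C(=O)c2ccc(OC)c3c2OC(C)(C)C=C3)cc1` differs from compound 3 by diethylamino in place of fluoro on an aromatic carbon. Within the data shown here, no step between two measured compounds exists in this set, so the size of the change has no measured counterpart here. The expectation for compound 4 is a modest move toward a measurable number, not much beyond the scatter, with a real chance that only a limit is reported again. Compound 4 is estimated at 5000 nM, expected between 1500 nM and 20000 nM. This estimate means a step of an at least 2.0-fold lower number from compound 3 to compound 4 (0.30 log units; that floor lies within the scatter) away from the limit, and it is an expectation only.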

Compound 4, half-maximal inhibitory concentration: 620 nM
Estimate against measurement, compound 4: 8.1-fold (0.91 log units) above; measured number outside the range, below it.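

In this assay, the place para to a large group on the aromatic ring turns out to be sensitive to its substituent: diethylamino in place of fluoro gives an at least 16-fold lower number from compound 3 to compound 4 (1.20 log units; beyond the scatter). Compound 3 gives > 10000 nM, which is a limit of the assay and not a number, so this step sets only a floor on the size of the change. This is the first single-place change in the series that can be read, and compound 4 lies clear of the limit: the limit of > 10000 nM in this assay, at which 2 of the 4 values shown sit.

The compounds shown leave open whether the step follows the nitrogen or the two ethyl chains; a plain amine, dimethylamino or a pyrrolidine at this place would separate the two. From the compounds shown here alone, whether a methoxy group or a hydroxyl at the same place also moves the value remains open as well.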